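Aryl swaps on the shared core: cytotoxicity notes

The source may hold more compounds than are shown below. What is called first, only, known or untested is meant among the compounds shown, and "the series" means these compounds.

Among the compounds with values here, compound 2 `COc1cc(N2C(N)=C(C#N)C(c3c(O)ccc4ccccc34)C3=C2CC(C)(C)CC3=O)cc(OC)c1OC` holds the higher of the two numbers so far in a functional assay on Ehrlich cells (Mus musculus) for cytotoxicity, tested at 10 ug/mL (a lower number here means a weaker effect, a higher number a stronger effect of the compound at the concentration tested), where compound 2 gives 2%. Within the data shown here, its nearest neighbour is compound 1 `COc1cc(N2C(N)=C(C#N)C(c3ccccc3O)C3=C2CC(C)(C)CC3=O)cc(OC)c1OC`, which in this assay gives 0%; the single measured step, a number 2 percentage points higher from compound 1 to compound 2 (within the scatter), lies within the scatter, so the two are not separable. Compound 3 `COc1cc(N2C(N)=C(C#N)C(c3cccc([N+](=O)[O-])c3)C3=C2CC(C)(C)CC3=O)cc(OC)c1OC` differs from compound 2 by 3-nitrophenyl in place of 2-hydroxynaphthalen-1-yl on a saturated ring carbon. Among the measured compounds shown here, no measured step brings in a nitro-bearing aryl group; the one step in hand, a number 2 percentage points higher from compound 1 to compound 2 (within the scatter), only shows that exchanging 2-hydroxyphenyl for 2-hydroxynaphthalen-1-yl on this saturated ring carbon left the read-out flat near the floor. Compound 3 is therefore expected to show a step of a number 1 percentage points higher from compound 2 to compound 3 (within the scatter), nothing beyond the scatter. Compound 3 is estimated at 3%, with a range from 0% to 18%.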

Compound 3, a percentage reported as activity, at one concentration (the size of the read-out at that concentration, not a potency): 5%
Beside the measured number, compound 3's estimate is 2 percentage points below it; the range from low to high includes it.
By their numbers in this assay, from the lowest: compounds 1, 2 and 3 (each within the scatter of the next).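

Within the data shown here, at the saturated ring carbon, 3-nitrophenyl is the first aryl group here that carries no hydroxyl, and in this assay the change reads as a number 3 percentage points higher from compound 2 to compound 3 (within the scatter) and as a number 5 percentage points higher from compound 1 to compound 3 (within the scatter). Among these compounds, neither the loss of the hydroxyl-bearing aryl groups nor the change from two aromatic rings to one separates these compounds, so all three stay within the scatter of one another and the position so far shows no response to the aryl group it carries. No supporting data bear on why the read-out stays flat.

Still open, from the compounds shown here alone, is whether an aryl ring bearing a carboxylic acid or an amine, or a plain alkyl chain in place of the aryl group, would lift the read-out clear of the scatter at this carbon. Also open, going by these compounds, is whether changing the 3,4,5-trimethoxyphenyl group would do so.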